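Bromine in Place of Fluorine on a Hydroxamic Acid Core

The compounds below may be only part of what the source reports. "The series", "measured", "known", "first", "only" and "open" are said of these compounds alone.

Of the compounds shown here, three built on one shared core have been tested so far, and all carry a different group on the ring nitrogen. Compound 1 `O=C(CCC1=CCCN(Cc2ccc(F)cc2)C1=O)NO` in a functional assay on HCT-15 cells (Homo sapiens) for inhibition, read by sulforhodamine B assay (on this read-out lower numbers stand for stronger inhibition of growth and higher numbers for weaker inhibition of growth), gives 9960 nM, the highest number of the three. Compound 2 `COc1cccc(CN2CCC=C(CCC(=O)NO)C2=O)c1` gives 9030 nM in this assay, a number within the scatter of that of compound 1, so the two cannot be told apart. Compound 3 `O=C(CCC1=CCCN(CCCCc2cccc3ccccc23)C1=O)NO` gives 1670 nM in this assay, the lowest of the three and beyond the scatter from compound 1, so compound 3 inhibits growth more strongly than compound 1 does.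

Compound 4 `O=C(CCC1=CCCN(Cc2ccc(Br)cc2)C1=O)NO` has not been measured yet. It differs from compound 1 in one place: bromo in place of fluoro on an aromatic carbon. Among the compounds with values here, no measured pair in this set shows such an exchange of one halogen for another, so its effect cannot be read from the data at hand. The expected step of a 1.5-fold lower number from compound 1 to compound 4 (0.19 log units; within the scatter) is therefore small, probably within the scatter, with a slight lean toward a lower number. Compound 4 is estimated at 6500 nM in this assay, with a range from 2500 nM to 16000 nM.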

Compound 4, concentration for 50% growth inhibition: 1720 nM
The estimate for compound 4 lay 3.8-fold (0.58 log units) above the measured number, and the stated range ends above it.
By their numbers in this assay, from the lowest: compounds 3 and 4 (each within the scatter of the next); then compounds 2 and 1 (each within the scatter of the next).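

In this assay, putting bromo in place of fluoro on the aromatic carbon gives a 5.8-fold lower number from compound 1 to compound 4 (0.76 log units; beyond the scatter). Within the data shown here, this is the first step in the set between compounds that differ in one place, and it shows that the choice of halogen on this carbon, para to a large group, can change growth inhibition beyond the scatter, even though only one heavy atom is exchanged and no ring, hydrogen-bond donor, hydrogen-bond acceptor or net charge enters or leaves. Nothing in the data at hand accounts for this step, so its cause remains unknown.

Going by these compounds, a single pair gives one step and no trend, so it remains open whether chloro on the same carbon would read like fluoro or like bromo, and whether a group without any halogen, such as methyl or trifluoromethyl, would do the same as bromo. Also open, on these data alone, is whether the exchange of fluoro for bromo gives a step of similar size when the aromatic ring hangs on a longer chain.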